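The source may report more compounds than this note shows. Statements on the series, on what has been measured and on what is new or still open speak of the compounds shown alone.

Compound 1 `O=C1N/C(=N/c2csc(-c3ccc(Cl)cc3)c2)S/C1=C\c1ccccc1`: in a functional assay on MCF7 cells (Homo sapiens) for cytotoxicity, read by MTT assay, with a stated time of 72 h (on this read-out lower numbers stand for stronger inhibition and higher numbers for weaker inhibition), compound 1 gives > 50000 nM, which is a limit of the assay rather than a number.
Compound 2 `COc1ccc(/C=C2\S/C(=N\c3csc(-c4ccc(Cl)cc4)c3)NC2=O)cc1`: in this assay compound 2 gives 1000 nM.
Compound 3 `O=C1N/C(=N/c2csc(-c3ccc(Cl)cc3)c2)S/C1=C\c1ccc(O)cc1`: in this assay compound 3 gives > 50000 nM, again a limit and not a number.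

Compound 3 therefore stands at the edge of what this assay can report, at the limit of > 50000 nM in this assay, at which 2 of the 3 values shown sit, and only a limit is known for it. Compound 4 `O=C1N/C(=N/c2csc(-c3ccc(Cl)cc3)c2)S/C1=C\c1ccc(F)cc1` differs from compound 3 by fluoro in place of hydroxy on an aromatic carbon. Among the compounds with values here, two measured steps touch this position. The step that the two limits leave unreadable from compound 1 to compound 3 cannot be read, as both ends are limits. The step of an at least 50-fold higher number from compound 2 to compound 3 (1.69 log units; beyond the scatter) is large, and mirrors an at least 50-fold lower number from compound 1 to compound 2 (1.69 log units; beyond the scatter), so among the three compounds only the methoxy-bearing compound 2 produced a number; compound 1 with hydrogen and compound 3 with hydroxy both sit at the limit. Nothing measured tells what fluoro at this carbon does, and the nearest comparisons, hydrogen and hydroxy, both gave limits. Compound 4 is therefore expected to remain at or near the limit, with an estimate of 50000 nM spanning 8000 nM to 200000 nM. The expected step of a number no higher from compound 3 to compound 4 (the limit leaves the size open) is thus none beyond the scatter.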

Compound 4, half-maximal inhibitory concentration: > 50000 nM
Compound 4 gave a limit, no number; the forecaster's own chance of this, stated with the estimate: 65%; the middle value lies on the limit itself.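

Replacing methoxy with fluoro on this aromatic carbon gives an at least 50-fold higher number from compound 2 to compound 4 (1.69 log units; beyond the scatter) in this assay, so fluoro, like hydrogen and hydroxy before it, does not give the measurable value seen with methoxy. The steps among compound 1, compound 3 and compound 4 cannot be read, as both ends of each are limits. Among these four compounds only methoxy gives a number, and the other three share one limit: the limit of > 50000 nM in this assay, at which 3 of the 4 values shown sit.

From the compounds shown here alone, how far compound 1, compound 3 and compound 4 lie beyond that limit remains unknown, so hydrogen, hydroxy and fluoro cannot be ranked against one another. Also open, going by these compounds, is whether the value depends on methoxy alone, or whether an ethoxy group or a dimethylamino group on this carbon would also give a number.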